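The source may report more compounds than this note shows. Statements on the series, on what has been measured and on what is new or still open speak of the compounds shown alone.

Measured compounds:
Compound 1 `CN(C)c1ccc(/C=C2/SC(=Nc3ccccc3)NC2=O)cc1` gives 210 nM in a functional assay on NCI-H460 cells (Homo sapiens) for antiproliferative activity; on this read-out lower numbers stand for stronger inhibition and higher numbers for weaker inhibition.
Compound 2 `O=C1N/C(=N\c2ccc(Cl)cc2)S/C1=C/c1ccccc1O` gives 1180 nM in this assay.

Of these two numbers, compound 1 has the lower one, and compound 2 lies a good deal higher, beyond the usual scatter. Compounds 1 and 2 differ in more than one place, so nothing is said here about any single change between them.

The step followed here leads from compound 1 to compound 3 `CN(C)c1ccc(/C=C2/SC(=Nc3ccc(O)cc3)NC2=O)cc1`, which has not yet been measured in this assay. The difference is hydroxy in place of hydrogen on an aromatic carbon. Going by the values given here, no pair of measured compounds shows this change on its own, so no measured step guides the expectation. The step of a 1.2-fold higher number from compound 1 to compound 3 (0.08 log units; within the scatter) is expected to stay within the usual scatter, in either direction. Compound 3 is therefore expected to give about 250 nM, with an estimated range from 80 nM to 800 nM.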

Compound 3, half-maximal inhibitory concentration: 1080 nM
Compound 3: middle estimate off by 4.3-fold (0.64 log units), on the low side; the whole stated range lies below it.
By their numbers in this assay, from the lowest: compound 1; then compounds 3 and 2 (each within the scatter of the next).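

In this assay, the change from phenyl to 4-hydroxyphenyl, with hydroxy in place of hydrogen on an aromatic carbon para to a large group, gives a 5.1-fold higher number from compound 1 to compound 3 (0.71 log units; beyond the scatter). Going by these compounds alone, this is the first reading of a single change, since compound 1 and compound 2 differ in more than one place, and it shows that inhibition at this position weakens when this one hydroxy enters. Nothing measured here accounts for the weakening.

As far as these compounds go, whether the same loss would follow with a methoxy group, a fluorine atom or an amine on this carbon remains open. Also open, from the compounds shown here alone, is whether hydroxy would give a similar step on another carbon of this ring, or on a compound with a different group elsewhere on the shared core.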